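Propoxy in place of nitro on the diacid anilide

A few compounds are considered here, and "the series" means these few. Any claim that something is new, unique, unknown or untested is made for them only; others in the source may bear on it.

Three compounds have numbers in a functional assay on the whole organism (stomach) with Rattus norvegicus as the target; on this read-out higher numbers stand for an effect only at larger amounts of compound and lower numbers for an effect already at smaller amounts. Within the data shown here, compound 1 `O=C(Nc1ccc(-c2nn[nH]n2)cc1)c1cccc(-c2nn[nH]n2)c1` gives 0.6 mg/kg, and compound 3 `O=C(Nc1ccccc1)c1cccc(-c2nn[nH]n2)c1` gives 38.1 mg/kg; the step of a 64-fold higher number from compound 1 to compound 3 (1.80 log units; beyond the scatter) is the only single-point change measured so far. Compound 2 `O=C(O)c1cc(NC(=O)c2ccc([N+](=O)[O-])cc2)cc(C(=O)O)c1` gives 61.1 mg/kg, the highest of the three numbers; its distance to compound 3 is within the scatter, while its distance to compound 1 is beyond it.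

Compound 4 `CCCOc1ccc(C(=O)Nc2cc(C(=O)O)cc(C(=O)O)c2)cc1` differs from compound 2 in one place: propoxy in place of nitro on an aromatic carbon.

Among the measured compounds shown here, no measured step concerns an exchange of this kind. For the measured compounds named here, the one step in hand, from tetrazolyl to hydrogen in this assay, touches a different group on a different scaffold, so it gives no guide to the size or direction of the present change. With nothing to point either way, the working expectation is that compound 4 stays close to compound 2, with any step expected to lie within the scatter.

Compound 4 is therefore estimated at 50 mg/kg in this assay, with a range from 15 mg/kg to 160 mg/kg, which means an expected step of a 1.2-fold lower number from compound 2 to compound 4 (0.09 log units; within the scatter).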

Compound 4, dose for 50% inhibition: 78 mg/kg
Compound 4: middle estimate off by 1.6-fold (0.19 log units), on the low side, and the stated range covers the measured number.
By their numbers in this assay, from the lowest: compound 1; then compounds 3, 2 and 4 (each within the scatter of the next, the first and the last beyond it).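

On the diacid anilide, at the aromatic carbon para to a large group, propoxy in place of nitro gives a 1.3-fold higher number from compound 2 to compound 4 (0.11 log units; within the scatter) in this assay and so leaves the read-out unable to separate these two groups at this position. Among these compounds, the two groups differ in their heavy atoms, in their hydrogen-bond acceptors and in the double bond outside aromatic rings, yet this pair shows no step beyond the scatter, unlike the one other single-point step. No measurement is available that bears on why this exchange gives so small a step.

From the compounds shown here alone, whether another group at this position, such as an amine, a hydroxyl or an alkoxy chain longer than propoxy, would give a step beyond the scatter remains open. Also open, going by these compounds, is whether 2H-tetrazol-5-yl at this position of the diacid anilide would count for as much as it does in the step of a 64-fold higher number from compound 1 to compound 3 (1.80 log units; beyond the scatter) on the other scaffold.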